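The source may report more compounds than this note shows. Statements on the series, on what has been measured and on what is new or still open speak of the compounds shown alone.

Measured in an assay on COS-7 cells for inhibition of patatin-like phospholipase domain-containing protein 2 (Mus musculus); a lower number here means a stronger inhibitor, a higher number a weaker inhibitor:

compound 1 `CCOC(=O)c1ccc(-c2ccc(OCC)cc2)s1`: 70000 nM
compound 2 `CCOC(=O)c1cccc(-c2ccc(C(C)=O)cc2)c1`: 200000 nM
compound 3 `CCOc1ccc(-c2cccc(S(=O)(=O)NC)c2)cc1`: 200000 nM

Compound 3 stands level with compound 2 at the digits given, the two together the highest numbers of the three; compound 1 sits a good deal lower, a gap beyond the scatter. Among the compounds with values here, no two measured compounds differ in a single place, so no step between measured compounds is available for guidance.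

Compound 4 `CCCCOC(=O)c1cccc(-c2ccc(OCC)cc2)c1` differs from compound 3 by butoxycarbonyl in place of methylsulfamoyl on an aromatic carbon. Compound 4 thus carries an ester on the core, as compound 1 and compound 2 do, together with the ethoxyphenyl that compound 1 and compound 3 share. Within the data shown here, a move to a lower number seems more likely than none, because compound 1, which combines an ester with the ethoxyphenyl, gives 70000 nM in this assay, although the butoxycarbonyl itself has no measured counterpart. The step from compound 3 to compound 4 is expected to be a 3.3-fold lower number from compound 3 to compound 4 (0.52 log units; beyond the scatter). For compound 4 the estimated value is 60000 nM, with a range from 15000 nM to 200000 nM.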

Compound 4, half-maximal inhibitory concentration: 100000 nM
The estimate for compound 4 lay 1.7-fold (0.22 log units) below the measured number; low and high end bracket the measured number.
By their numbers in this assay, from the lowest: compounds 1, 4, 2 and 3 (each within the scatter of the next, the first and the last beyond it).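

In this assay, within the data shown here, exchanging methylsulfamoyl for butoxycarbonyl on an aromatic carbon, with the ethoxyphenyl unchanged, gives a 2.0-fold lower number from compound 3 to compound 4 (0.30 log units; within the scatter) and is the first single-place step. At this position, the two groups are therefore not separated by this measurement, even though they differ in size and butoxycarbonyl has no hydrogen-bond donor, and an ester here offers no clear gain over methylsulfamoyl. No measurement on the compounds accounts for this outcome.

Going by these compounds, it remains open whether a shorter chain such as ethoxycarbonyl, a longer chain, or a carboxylic acid at the same aromatic carbon would move the number beyond the scatter. Among these compounds, the separate contribution of the ethoxy group also remains open, as no step isolates it from the rest of the series.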